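Swapping the imidazolyl ring for a fused bicyclic group

This account rests on a few compounds, and the source may have more. Where it says the series, first, only, none or still open, it means among the compounds named here.

Measured so far:
compound 1, `Cc1cc(-c2ccco2)c2ncc(CSCCc3ccccc3)n2c1`: 100 ug/mL
compound 2, `Cc1cc(-n2ccnc2)c2ncc(CSCCc3ccccc3)n2c1`: 20 ug/mL

Two compounds have been examined in an ADME assay on HEL cells (Homo sapiens) for cytotoxicity, with a stated time of 3 days; a lower number here means that less compound is tolerated, a higher number that more compound is tolerated. Compound 1 gives 100 ug/mL. Among the measured compounds shown here, compound 2 gives 20 ug/mL, which is the lowest of the two numbers; its nearest neighbour is compound 1, and the single measured step, a 5.0-fold lower number from compound 1 to compound 2 (0.70 log units; beyond the scatter), is the only one that bears on what follows. That step also exchanges one aromatic ring for another on the same aromatic carbon of the shared core, and it moved the number by a modest amount beyond the scatter.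

Compound 3, `Cc1cc(-n2ccc3cccnc32)c2ncc(CSCCc3ccccc3)n2c1`, has not yet been measured. It differs from compound 2 as follows: a group of 9 heavy atoms (7 carbon, 2 nitrogen; one five-membered aromatic ring with 1 hetero atom, one six-membered aromatic ring with 1 hetero atom) in place of a group of 5 heavy atoms (3 carbon, 2 nitrogen; one five-membered aromatic ring with 2 hetero atoms), on an aromatic carbon. For the measured compounds named here, no measured pair shows the effect of enlarging the ring at this carbon into a fused two-ring group, so the one measured step gives a sense of scale but no direction. Compound 3 is therefore expected to stay close to compound 2, with a step of no change at the digits printed from compound 2 to compound 3 (within the scatter) that may well fall within the scatter. The estimate for compound 3 in this assay is 20 ug/mL, with a range from 4 ug/mL to 100 ug/mL.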

Compound 3, minimum cytotoxic concentration: 100 ug/mL
For compound 3 the middle estimate is 5.0-fold (0.70 log units) below the measured one; the measured number falls inside the stated range.
By their numbers in this assay, from the lowest: compound 2; then compounds 1 and 3 (each within the scatter of the next).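

Replacing the 1H-imidazol-1-yl group with the fused two-ring group at this aromatic carbon in this assay gives a 5.0-fold higher number from compound 2 to compound 3 (0.70 log units; beyond the scatter), so a larger group of 9 heavy atoms here does not bring the number down. The fused group and furan-2-yl show no change at the digits printed from compound 1 to compound 3 (within the scatter), which leaves compound 2 as the only one of the three set apart at this position, although the furan-2-yl group has 5 heavy atoms, as 1H-imidazol-1-yl has, and the fused group has 9. The fused group and 1H-imidazol-1-yl also carry the same counts of nitrogen atoms and hydrogen-bond acceptors, so among these compounds neither ring size nor those counts alone follow the number.

Nothing available on these compounds accounts for why compound 2 stands apart. Going by these compounds, it remains open whether an amine, a methoxy group or a carboxylic acid on this aromatic carbon would group with compound 2 or with compounds 1 and 3, and whether another fused ring system would match compound 3.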